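Carbonyl substituent step from compound 2 to compound 3

The compounds below may be only part of what the source reports. "The series", "measured", "known", "first", "only" and "open" are said of these compounds alone.

- compound 1 `COc1cc(C(=O)N2CCCC2(C)C)cc2nc(NCc3cccc(Cl)c3)oc12` gives 58.3 mL/min/kg
- compound 2 `COc1cc(C(=O)N2CC[C@@H](O)C(C)(C)C2)cc2nc(NCc3cccc(Cl)c3)oc12` gives 51.7 mL/min/kg

In an ADME assay on cells (Hepatocyte, Rattus norvegicus, strain Wistar) for pharmacokinetics, read by LC-MS, with a stated time of 90 min, tested at 1 uM (on this read-out higher numbers stand for fast clearance and lower numbers for slow clearance), compound 2 stands level with compound 1 within the scatter, and these two numbers are the only reference points so far.

Compound 3 `COc1cc(C(=O)N2CCC(O)C(C)C2)cc2nc(NCc3cccc(Cl)c3)oc12` has not yet been measured. Its change from compound 2 is 4-hydroxy-3-methylpiperidin-1-yl in place of 4-hydroxy-3,3-dimethylpiperidin-1-yl on a carbonyl carbon, on a carbonyl carbon whose other neighbour is an aromatic carbon.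

Within the data shown here, one measured step bears on this change: a 1.1-fold lower number from compound 1 to compound 2 (0.05 log units; within the scatter). That step exchanged the whole group on the same carbonyl carbon and stayed within the scatter. Among the measured compounds shown here, no measured step isolates the present change, so the evidence is indirect and gives no direction. A step within the scatter is therefore expected, with neither direction favoured. The estimated step is a 1.0-fold lower number from compound 2 to compound 3 (0.01 log units; within the scatter).

In this assay the expected value for compound 3 is 50 mL/min/kg, with an estimated range from 32 mL/min/kg to 72 mL/min/kg.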

Compound 3, clearance: 45 mL/min/kg
Estimate against measurement, compound 3: 1.1-fold (0.05 log units) above; the range from low to high includes it.
By their numbers in this assay, from the lowest: compounds 3, 2 and 1 (each within the scatter of the next).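

In this assay, among these compounds, 4-hydroxy-3-methylpiperidin-1-yl in place of 4-hydroxy-3,3-dimethylpiperidin-1-yl gives a 1.1-fold lower number from compound 2 to compound 3 (0.06 log units; within the scatter) as the first measured step confined to the substituents of the six-membered ring, and that step lies within the scatter. Set against the 2,2-dimethylpyrrolidin-1-yl group, the same 4-hydroxy-3-methylpiperidin-1-yl group gives a 1.3-fold lower number from compound 1 to compound 3 (0.11 log units; within the scatter) in this assay, also within the scatter, so the three groups on this carbonyl carbon stand level and yield no order or trend, despite the differences in ring size and heavy-atom count between them. No accompanying measurement is available to explain these numbers.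

The compounds shown leave open whether any group on this carbonyl carbon can move the clearance number beyond the scatter, for example a piperidine ring carrying a carboxylic acid or an amine in place of the hydroxy group. Compound 3 also has no defined stereocentre in its entering group, so the values of its individual stereoisomers remain an open question.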